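The source may report more compounds than this note shows. Statements on the series, on what has been measured and on what is new or still open speak of the compounds shown alone.

Measured compounds:
- compound 1 `CCCCc1cc2ccccc2nc1-c1cc(-c2ccc(C)cc2)no1`: > 100000 nM in a functional assay on PC-3 cells (Homo sapiens) for inhibition, read by MTT assay, with a stated time of 24 h; on this read-out higher numbers stand for weaker inhibition and lower numbers for stronger inhibition
- compound 2 `CCCCCc1cc2ccccc2nc1-c1cc(-c2ccc(C)cc2)no1`: > 100000 nM in this assay

Compound 1 stands only at a limit of this assay, not at a number. Compound 2 likewise sits at a limit of this assay. Both shown values therefore rest at the limit of > 100000 nM in this assay, at which 2 of the 2 values shown sit. Within the data shown here, the one measured step, a step that the two limits leave unreadable from compound 1 to compound 2, changes a chain on the shared core and cannot be read in size, because the limit of > 100000 nM in this assay, at which 2 of the 2 values shown sit, hides where either compound truly lies.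

Compound 3 `CCCCc1cc2ccccc2nc1-c1cc(-c2ccc(C(F)(F)F)cc2)no1` differs from compound 1 by trifluoromethyl in place of methyl on an aromatic carbon, on the phenyl attached to the core rather than on the chain. No measured step touches this ring, so the step that the two limits leave unreadable from compound 1 to compound 2 gives no direct guide, and nothing beyond the scatter can be expected in either direction from the numbers shown. Compound 3 is expected to stay near the same limit, at 150000 nM (range 40000 nM to 500000 nM), a step that the limit leaves unreadable from compound 1 to compound 3.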

Compound 3, half-maximal inhibitory concentration: 10800 nM
The estimate for compound 3 lay 14-fold (1.14 log units) above the measured number; the whole stated range lies above it.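

Trifluoromethyl in place of methyl on an aromatic carbon, para to a large group, is the first change shown that yields a readable number: in this assay, it gives an at least 9.2-fold lower number from compound 1 to compound 3 (0.96 log units; beyond the scatter). Compound 1 gives > 100000 nM, which is a limit and not a number, so the true size of this step may be larger than the stated minimum. This place on the ring can therefore change the read-out, and compound 3 is the only compound shown that stands clear of the limit: the limit of > 100000 nM in this assay, at which 2 of the 3 values shown sit.

On these data alone, whether this drop is specific to trifluoromethyl remains open, as a chlorine atom, a methoxy group or an amine at the same place could give a higher or a lower number. As far as these compounds go, it is also open whether the same change would lower the number on the chain of compound 2.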